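Swapping the aryl ring on the chalcone carbonyl

This account rests on a few compounds, and the source may have more. Where it says the series, first, only, none or still open, it means among the compounds named here.

Compound 1 `COC(=O)c1cc(-c2cccc(NC(=O)c3ccc(OCc4ccc(Cl)cc4)cc3)c2)on1` gives > 80 ug/mL, a limit of the assay rather than a number.
Compound 2 `COC(=O)c1cc(-c2cccc(NC(=O)c3ccc(/C=C/C(=O)c4ccc(Br)cc4)cc3)c2)on1` gives > 20 ug/mL, again only a limit.
Compound 3 `COC(=O)c1cc(-c2cccc(NC(=O)c3ccc(/C=C/C(=O)c4ccc(Cl)cc4Cl)cc3)c2)on1` gives > 40 ug/mL, likewise a limit.

All three values come from an ADME assay on Vero cells (Chlorocebus sabaeus) for cytotoxicity, read by MTT assay, with a stated time of 72 h; a lower number here means that less compound is tolerated, a higher number that more compound is tolerated. Compound 3 therefore stands at a limit, and the two other values shown are limits as well, so none of the three can be ranked against another. Among the measured compounds shown here, the step that the two limits leave unreadable from compound 1 to compound 2 and the step that the two limits leave unreadable from compound 1 to compound 3 cannot be read, and the same holds for the step that the two limits leave unreadable from compound 2 to compound 3, which is the one most like the change at hand. The evidence on these steps is only (the limit of > 20 ug/mL in this assay, at which 1 of the 3 values shown sits), the limit of > 40 ug/mL in this assay, at which 1 of the 3 values shown sits, and (the limit of > 80 ug/mL in this assay, at which 1 of the 3 values shown sits).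

Compound 4 `COC(=O)c1cc(-c2cccc(NC(=O)c3ccc(/C=C/C(=O)c4cccc(Br)c4)cc3)c2)on1` differs from compound 3 by 3-bromophenyl in place of 2,4-dichlorophenyl on a carbonyl carbon. For the measured compounds named here, the step from compound 2 to compound 3 is the only one that changes the aryl ring on the carbonyl carbon, and its size is unreadable, so no step beyond the scatter can be predicted in this assay. Compound 4 is expected to give 40 ug/mL, within a range from 20 ug/mL to 80 ug/mL. The step of a number no higher from compound 3 to compound 4 (the limit leaves the size open) is therefore estimated to be no change beyond the scatter, and most likely another limit.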

Compound 4, half-maximal cytotoxic concentration: > 100 ug/mL
Compound 4 ended at the assay's limit (the forecaster's own chance of this, stated with the estimate: 85%); at least 2.5-fold (0.39 log units) between middle value and limit.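

In this assay compound 4 gives > 100 ug/mL, a limit of the assay and not a number. Compound 1, compound 2 and compound 3 also stand at limits, and none of the steps linking them to compound 4 can be read. The compounds shown leave open where the real value of each lies, and whether changing the aryl ring on the carbonyl carbon shifts it at all.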